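A Chloro Group Added to Two Related Cores

The source may hold more compounds than are shown below. What is called first, only, known or untested is meant among the compounds shown, and "the series" means these compounds.

Of the compounds shown here, three have been tested so far in a functional assay on cells (Cancer cell lines, Homo sapiens) for cytotoxicity, with a stated time of 48 h; a higher number here means a weaker inhibitor of growth, a lower number a stronger inhibitor of growth. Compound 1 `COc1c(/C=C2/C(=O)Nc3ccccc32)c2ccccc2n1-c1ccccc1` gives 1050 nM in this assay. Compound 3 `COc1c(/C=C2/C(=O)Nc3ccc(Cl)cc32)c2ccccc2n1-c1ccccc1` differs from compound 1 by chloro in place of hydrogen on an aromatic carbon, and in this assay compound 3 gives 6310 nM, so that the step of a 6.0-fold higher number from compound 1 to compound 3 (0.78 log units; beyond the scatter) weakens growth inhibition. Compound 2 `O=C1Nc2ccccc2/C1=C\c1c(Cl)n(CCCc2ccccc2)c2ccccc12` has a different core; the difference between the two cores is not broken down here. In this assay compound 2 gives 12000 nM, the highest of the three numbers, though its value sits within the scatter of compound 3 and is beyond the scatter of compound 1.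

Compound 4 `O=C1Nc2ccc(Cl)cc2/C1=C\c1c(Cl)n(CCCc2ccccc2)c2ccccc12` has not yet been measured. It differs from compound 2 by chloro in place of hydrogen on an aromatic carbon, the same change as that from compound 1 to compound 3. Compound 4 is expected to give about 45000 nM in this assay, because the step of a 6.0-fold higher number from compound 1 to compound 3 (0.78 log units; beyond the scatter) already weakened growth inhibition on the other core. The expected step of a 3.8-fold higher number from compound 2 to compound 4 (0.57 log units; beyond the scatter) is estimated at a similar size, with a range from 15000 nM to 130000 nM to allow for the cores not being the same.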

Compound 4, concentration for 50% growth inhibition: 1950 nM
The estimate for compound 4 lay 23-fold (1.36 log units) above the measured number; the measured number lies below the stated range.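

In this assay, chloro in place of hydrogen on an aromatic carbon strengthens growth inhibition on this core, a 6.2-fold lower number from compound 2 to compound 4 (0.79 log units; beyond the scatter). The same change therefore does not carry over from one core to the other in this series, and here even its direction differs: the same change on two cores in this assay, a 6.0-fold higher number (0.78 log units; beyond the scatter) from compound 1 to compound 3 and a 6.2-fold lower number (0.79 log units; beyond the scatter) from compound 2 to compound 4, 37-fold (1.57 log units) apart, beyond the scatter of two such steps This pair shows that a step measured on one core cannot simply be transferred to the other, but it does not show which difference between the cores reverses the step, as they differ in more than one place, or how the change would behave on a third core.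

On these data alone, it remains open whether a fluoro group, a bromo group or an amine on the same aromatic carbon would split the two cores in the same way. Also open, as far as these compounds go, is whether a shorter or longer chain on the core of compound 2 would keep the gain seen with chloro.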